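Inverting the chain stereocentre of compound 3

A few compounds are considered here, and "the series" means these few. Any claim that something is new, unique, unknown or untested is made for them only; others in the source may bear on it.

Compound 1 `COc1cc[nH]c1/C=C1\C(=O)Nc2ccc(F)c(I)c21` carries iodo on an aromatic carbon of the shared core. In a functional assay on MDA-MB-435 cells (Homo sapiens) for inhibition (a higher number here means a weaker inhibitor, a lower number a stronger inhibitor), compound 1 reaches only the limit > 30000 nM, a boundary of the measurement rather than a number. Compound 2 `COc1cc[nH]c1/C=C1\C(=O)Nc2ccc(F)c(C#C[C@H](N)CO)c21` gives 320 nM in this assay, and the step of an at least 93-fold lower number from compound 1 to compound 2 (1.97 log units; beyond the scatter) is large. Compound 3 `CN[C@@H](C#Cc1c(F)ccc2c1/C(=C/c1[nH]ccc1OC)C(=O)N2)CO` gives 300 nM in this assay; the step of an at least 100-fold lower number from compound 1 to compound 3 (2.00 log units; beyond the scatter) is likewise large, while the step of a 1.1-fold lower number from compound 2 to compound 3 (0.03 log units; within the scatter) is within the scatter. Compound 3 and compound 2 thus sit together, and the remaining value of the series is a limit (the limit of > 30000 nM in this assay, at which 1 of the 3 values shown sits).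

Compound 4 `CN[C@H](C#Cc1c(F)ccc2c1/C(=C/c1[nH]ccc1OC)C(=O)N2)CO` differs from compound 3 in the two compounds have the same atoms and bonds and differ only in configuration as drawn: 1 of 2 stereo elements differ; a stereocentre at a saturated chain carbon is drawn S in compound 3 and R in compound 4. Within the data shown here, no measured step touches configuration at this carbon; the one step within the 4-hydroxybut-1-yn-1-yl chain, a 1.1-fold lower number from compound 2 to compound 3 (0.03 log units; within the scatter), changes only substitution on the amine nitrogen and was within the scatter, so the direction of the new step is unconstrained by the data. The step from compound 3 to compound 4 is expected to be a 2.3-fold higher number from compound 3 to compound 4 (0.37 log units; beyond the scatter), with wide uncertainty. For compound 4 the estimate in this assay is 700 nM, within 150 nM to 4000 nM.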

Compound 4, half-maximal inhibitory concentration: 349 nM
For compound 4 the middle estimate is 2.0-fold (0.30 log units) above the measured one; the measured number falls inside the stated range.
By their numbers in this assay, from the lowest: compounds 3, 2 and 4 (each within the scatter of the next). At a limit, above all of these: compound 1.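

The step of a 1.2-fold higher number from compound 3 to compound 4 (0.07 log units; within the scatter) shows that S and R at the saturated chain carbon cannot be told apart in this assay, and the comparison is a clean one: the fact that compounds 3 and 4 differ only in the configuration as drawn. The step of a 1.1-fold higher number from compound 2 to compound 4 (0.04 log units; within the scatter) adds that the inverted methylamine also cannot be told apart from the primary amine. Compound 1 stands at a limit and not a number, so the step of an at least 85-fold lower number from compound 1 to compound 4 (1.93 log units; beyond the scatter) is only a bound, and the large drop from iodo to the chain now holds for both drawn configurations: the limit of > 30000 nM in this assay, at which 1 of the 4 values shown sits.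

Open, from the compounds shown here alone, is whether configuration stays as silent with a dimethylamino group on that carbon or with a longer chain in place of the hydroxymethyl end. Also open, going by these compounds, is whether the amine or the hydroxyl is needed at all for the numbers these chains give.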